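Working notes: cytotoxicity, step from compound 3 to compound 4

The compounds below may be only part of what the source reports. "The series", "measured", "known", "first", "only" and "open" are said of these compounds alone.

Measured so far:
Compound 1 `Oc1ccc(-c2nc3cc(C(F)(F)F)ccc3[nH]2)cc1`: > 100000 nM
Compound 2 `Cn1c(-c2ccc([N+](=O)[O-])cc2)nc2cc(C(F)(F)F)ccc21`: > 100000 nM
Compound 3 `CN1CCN(CC(=O)Nc2ccc(-c3nc4cc(C(F)(F)F)ccc4n3C)cc2)CC1`: 16000 nM

Three compounds carry results in an ADME assay on BHK cells (Mesocricetus auratus) for cytotoxicity, read by MTT assay, with a stated time of 96 h; on this read-out lower numbers stand for higher toxicity in this test and higher numbers for lower toxicity in this test. For compound 1 the result is a limit of the assay, > 100000 nM. For compound 2 the result is likewise a limit, > 100000 nM. Within the data shown here, compound 3 gives 16000 nM, the only numerical value among the three. The other two results sit at the limit of > 100000 nM in this assay, at which 2 of the 3 values shown sit.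

Compound 4 `Cn1c(-c2ccc(NC(=O)CN3CCCC3)cc2)nc2cc(C(F)(F)F)ccc21` is the next compound for this assay. It differs from compound 3 in one place: pyrrolidin-1-yl in place of 4-methylpiperazin-1-yl on a saturated chain carbon bound to a carbonyl carbon. Among the measured compounds shown here, no step between measured compounds covers a change of this kind, so no measured step in this assay can be pointed to, and the expectation rests on compound 3 alone with 16000 nM.

Compound 4 is expected to give 20000 nM, between 6000 nM and 70000 nM. The implied step, a 1.3-fold higher number from compound 3 to compound 4 (0.10 log units; within the scatter), is expected to stay within the usual scatter, in no set direction.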

Compound 4, half-maximal cytotoxic concentration: 27000 nM
Estimate against measurement, compound 4: 1.4-fold (0.13 log units) below; measured number inside the range.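

In this assay, pyrrolidin-1-yl in place of 4-methylpiperazin-1-yl on a saturated chain carbon bound to a carbonyl carbon gives a 1.7-fold higher number from compound 3 to compound 4 (0.23 log units; within the scatter), so this read-out does not tell the two rings apart at this place. Among these compounds, the change at the aromatic carbon, (((pyrrolidin-1-yl)methyl)carbonyl)amino in place of nitro, gives an at least 3.7-fold lower number from compound 2 to compound 4 (0.56 log units; beyond the scatter), the first step beyond the scatter, and it ties the appearance of a measured number in compound 4 to this side chain. That step has only a bound on its size because its starting value, for compound 2, is a limit of the assay: the limit of > 100000 nM in this assay, at which 2 of the 4 values shown sit.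

Going by these compounds, whether an open-chain amine such as dimethylamino, or a morpholin-4-yl ring, would read like these two rings at the same place remains open. Also open, on these data alone, is whether a longer chain between the carbonyl and the ring would keep the read-out in this range.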